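Compound 3 and an added isopropoxy group

A few compounds are considered here, and "the series" means these few. Any claim that something is new, unique, unknown or untested is made for them only; others in the source may bear on it.

In a functional assay on A549 cells (Homo sapiens) for antiproliferative activity, read by sulforhodamine B assay, with a stated time of 72 h (a lower number here means a stronger inhibitor, a higher number a weaker inhibitor), compound 3 `O=C(/C=C/c1csc2ccccc12)c1ccccc1O` gives 5300 nM. On the same measure, compound 1 `COc1c(OC(C)C)cc2occ(-c3csc4ccccc34)c(=O)c2c1OC(C)C` gives 8900 nM, a value within the scatter of that for compound 3. Compound 2 `COc1c(OC(C)C)cc2oc(-n3cncn3)c(-c3csc4ccccc34)c(=O)c2c1OC(C)C` reads > 10000 nM, which is a limit of the assay. Compound 4 `CC(C)Oc1ccc(O)c(C(=O)/C=C/c2csc3ccccc23)c1` differs from compound 3 by one change, isopropoxy in place of hydrogen on an aromatic carbon. For the measured compounds named here, the only measured step, an at least 1.1-fold higher number from compound 1 to compound 2 (0.05 log units; that floor lies within the scatter), concerns a different group on a different core, so its size offers little guidance here. With compound 3 at 5300 nM as the closest reference, no step beyond the scatter is expected in either direction. The estimated step is a 1.2-fold lower number from compound 3 to compound 4 (0.07 log units; within the scatter). Compound 4 is expected at 4500 nM, within an estimated range of 1500 nM to 12000 nM.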

Compound 4, half-maximal inhibitory concentration: 6400 nM
Compound 4: middle estimate off by 1.4-fold (0.15 log units), on the low side; the range from low to high includes it.
By their numbers in this assay, from the lowest: compounds 3, 4 and 1 (each within the scatter of the next). At a limit, above all of these: compound 2.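

Setting isopropoxy in place of hydrogen on this aromatic carbon, para to a hydroxy group and meta to a large group, gives a 1.2-fold higher number from compound 3 to compound 4 (0.08 log units; within the scatter) in this assay. The two compounds thus stand within the scatter of each other, so this position carries isopropoxy without a difference that can be read. Nothing at hand bears on the reason for this result.

Going by these compounds, whether methoxy, an amine or a carboxylic acid at this same position would read differently stays open.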